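A few compounds are considered here, and "the series" means these few. Any claim that something is new, unique, unknown or untested is made for them only; others in the source may bear on it.

Measured so far:
Compound 1, `CCCCOC(=O)N1CCC(Oc2ncnc3c2CCN3c2ccc(S(C)(=O)=O)cc2F)CC1`, gives 131% in a functional assay on CHO-K1 cells with Glucose-dependent insulinotropic receptor (Homo sapiens) as the target, read by a luciferase reporter, with a stated time of 5 h; a higher number here means a larger maximal response, a lower number a smaller maximal response.
Compound 2, `COCCOC(=O)N1CCC(Oc2ncnc3c2CCN3c2ccc(S(C)(=O)=O)cc2F)CC1`, gives 86%.

Compound 2 stands lowest of the two numbers; its nearest neighbour is compound 1, and the step of a number 45 percentage points lower from compound 1 to compound 2 (beyond the scatter) lies beyond the scatter. Compound 3, `CC(C)S(=O)(=O)N1CCC(Oc2ncnc3c2CCN3c2ccc(S(C)(=O)=O)cc2F)CC1`, differs from compound 2 in one place: isopropylsulfonyl in place of (2-methoxyethoxy)carbonyl on an amine nitrogen in a ring. Among the compounds with values here, only one measured step exists, and it alters the chain of the carbamate, not the carbamate itself, so it bears only loosely on this change. No shift beyond the scatter is therefore expected. Compound 3 is expected to give 95%, in the range 60% to 135%. That estimate means a number 9 percentage points higher from compound 2 to compound 3 (within the scatter).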

Compound 3, largest response reached (reported as percent of maximum), in percent of the reference or control that the assay uses: 62%
For compound 3 the middle estimate is 33 percentage points above the measured one, and the stated range covers the measured number.
By their numbers in this assay, from the lowest: compound 3; then compound 2; then compound 1.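

On the amine nitrogen in the ring, exchanging the whole carbamate group for a sulfonyl group, and not only altering the chain of the carbamate, changes the maximal response in this assay. With isopropylsulfonyl the record shows a number 24 percentage points lower from compound 2 to compound 3 (beyond the scatter), and from the butoxycarbonyl compound it shows a number 69 percentage points lower from compound 1 to compound 3 (beyond the scatter), so both carbamates stand clear of the sulfonyl compound. No measurement here offers an explanation for these steps.

As far as these compounds go, it remains open whether the sulfonyl link or its isopropyl end sets these steps; a butylsulfonyl group on the same nitrogen would separate the two. From the compounds shown here alone, how an amide or a urea there would compare is also open.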